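Chloro for Fluoro on Two Related Cores

This account rests on a few compounds, and the source may have more. Where it says the series, first, only, none or still open, it means among the compounds named here.

Compound 1 `NC1CCN(c2c(F)cc3c(=O)c(C(=O)O)cn(C4CC4)c3c2F)CC1` and compound 2 `NC1CCN(c2c(F)cc3c(=O)c(C(=O)O)cn(C4CC4)c3c2Cl)CC1` were tested in a functional assay on V79 cells (Cricetulus griseus) for cytotoxicity, read by colony formation (on this read-out higher numbers stand for weaker inhibition and lower numbers for stronger inhibition), where compound 1 gives 23 ug/mL and compound 2 gives 18 ug/mL. The two differ only at one aromatic carbon, (chloro in place of fluoro on an aromatic carbon), and the step of a 1.3-fold lower number from compound 1 to compound 2 (0.11 log units; within the scatter).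

Compound 3 `Nc1c(F)c(N2CCC(N)C2)c(F)c2c1c(=O)c(C(=O)O)cn2C1CC1` carries a different core; how it differs from the core of compound 1 is not broken down here. In this assay compound 3 gives 15 ug/mL, and the three values sit within the scatter of one another.

Compound 4 `Nc1c(F)c(N2CCC(N)C2)c(Cl)c2c1c(=O)c(C(=O)O)cn2C1CC1` has not yet been measured. It differs from compound 3 by chloro in place of fluoro on an aromatic carbon. This is the same kind of change as that from compound 1 to compound 2, though the surroundings differ: here the carbon is ortho to a 3-aminopyrrolidin-1-yl group and para to an amino group, whereas in compound 1 it is ortho to a 4-aminopiperidin-1-yl group.

Because the earlier step of a 1.3-fold lower number from compound 1 to compound 2 (0.11 log units; within the scatter) stayed within the scatter, a similarly small step is expected, a 1.3-fold lower number from compound 3 to compound 4 (0.10 log units; within the scatter). Compound 4 is therefore estimated at 12 ug/mL, likely between 6 ug/mL and 25 ug/mL.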

Compound 4, half-maximal inhibitory concentration: 59 ug/mL
Compound 4: middle estimate off by 4.9-fold (0.69 log units), on the low side; the whole stated range lies below it.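

In this assay, chloro in place of fluoro on an aromatic carbon gave a 3.9-fold higher number from compound 3 to compound 4 (0.59 log units; beyond the scatter), so on the core of compound 3 the change moved the read-out towards weaker inhibition, which the core of compound 1 did not show. Set side by side, the two steps differ: the same change on two cores in this assay, a 1.3-fold lower number (0.11 log units; within the scatter) from compound 1 to compound 2 and a 3.9-fold higher number (0.59 log units; beyond the scatter) from compound 3 to compound 4, 5.0-fold (0.70 log units) apart, beyond the scatter of two such steps This shows that the outcome of this change did not carry over from one core to the other in this series, but with a single pair on each core it does not show which difference between the cores matters, whether the 3-aminopyrrolidin-1-yl group, the amino group or something else.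

The compounds shown leave open whether the step seen on the core of compound 3 would persist with a 4-aminopiperidin-1-yl group in place of the 3-aminopyrrolidin-1-yl group, or without the amino group. They also leave open how a bromo or methoxy group on that same aromatic carbon would read on either core.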